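Losing the Benzyl Group: What Happens to Compound 4?

This account rests on a few compounds, and the source may have more. Where it says the series, first, only, none or still open, it means among the compounds named here.

Compound 1 `COC(=O)[C@H](C)Nc1cc(CS(=O)(=O)/C=C/c2c(OC)cc(OC)cc2OC)ccc1OC`: 200 nM
Compound 2 `COC(=O)C(F)(F)Nc1cc(CS(=O)(=O)/C=C/c2c(OC)cc(OC)cc2OC)ccc1OC`: 250 nM
Compound 3 `COC(=O)C(Nc1cc(CS(=O)(=O)/C=C/c2c(OC)cc(OC)cc2OC)ccc1OC)c1ccccc1`: 30 nM

These values come from a functional assay on K562 cells (Homo sapiens) for cytotoxicity, read by trypan blue exclusion, with a stated time of 96 h; a lower number here means a stronger inhibitor, a higher number a weaker inhibitor. Compound 3 has the lowest number of the three, and its gaps to both others lie beyond the scatter. The next compound, compound 4 `COc1cc(OC)c(/C=C/S(=O)(=O)Cc2ccc(OC)c(NCCC(=O)O)c2)c(OC)c1`, has not been measured. The change from compound 3 is 2-carboxyethyl in place of methoxycarbonyl)(benzyl on a nitrogen on an aromatic ring.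

Within the data shown here, two measured steps bear on this: a 6.7-fold lower number from compound 1 to compound 3 (0.82 log units; beyond the scatter) and an 8.3-fold lower number from compound 2 to compound 3 (0.92 log units; beyond the scatter). In both, the group with the aromatic ring enters and the number falls. Compound 4 removes that ring, so these steps suggest a rise of similar size. The step of a 1.3-fold higher number from compound 1 to compound 2 (0.10 log units; within the scatter) shows that swapping between the two ringless groups changed little. Among the measured compounds shown here, no measured compound carries 2-carboxyethyl, so the uncertainty is wide.

The expected change is a 10-fold higher number from compound 3 to compound 4 (1.00 log units; beyond the scatter). Compound 4 is estimated at 300 nM, with an expected range from 80 nM to 1200 nM.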

Compound 4, half-maximal inhibitory concentration: 5000 nM
For compound 4 the middle estimate is 17-fold (1.22 log units) below the measured one, and the stated range ends below it.
By their numbers in this assay, from the lowest: compound 3; then compounds 1 and 2 (each within the scatter of the next); then compound 4.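

In this assay, among these compounds, the group on this nitrogen proves able to move the number much further than the earlier compounds showed, with a 170-fold higher number from compound 3 to compound 4 (2.22 log units; beyond the scatter) as the largest step in the set. The ring is not the whole story, since compound 1 and compound 2 also carry no ring on this nitrogen, yet 2-carboxyethyl stands well apart from both, with a 25-fold higher number from compound 1 to compound 4 (1.40 log units; beyond the scatter) and a 20-fold higher number from compound 2 to compound 4 (1.30 log units; beyond the scatter) as the steps. Nothing available here explains why this change costs so much.

The compounds shown leave open whether the rise follows the free carboxylic acid or the ringless chain that carries it. A 2-(methoxycarbonyl)ethyl group, a primary amide or a longer chain ending in a carboxylic acid, placed on the same nitrogen, would help separate these two possibilities.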